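The compounds below may be only part of what the source reports. "The series", "measured", "known", "first", "only" and "open" are said of these compounds alone.

Working notes on the series: in a functional assay on MT4 cells (Homo sapiens) for inhibition (on this read-out higher numbers stand for weaker inhibition and lower numbers for stronger inhibition), compound 1 (`C=C1[C@@H](O)[C@H](n2ccc(=O)[nH]c2=O)O[C@@H]1CO`) gives 450000 nM as its value. Compound 2 (`C=C1[C@@H](O)[C@H](n2cnc3c(N)nc(N)nc32)O[C@@H]1CO`) stands at > 200000 nM and this is a limit of the assay, not a number. Compound 3 (`C=C1[C@@H](O)[C@H](n2cnc3c(S)nc(N)nc32)O[C@@H]1CO`) carries sulfanyl in place of amino on an aromatic carbon. Within the data shown here, no measured step covers this swap, so the expectation rests on the structural change alone. The estimated move is an at least 6.6-fold lower number from compound 2 to compound 3 (0.82 log units; beyond the scatter) and it is expected to run toward stronger inhibition, beyond the scatter. In this assay the expected value for compound 3 is 30000 nM with an estimated range from 3000 nM to 200000 nM.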

Compound 3, half-maximal inhibitory concentration: 12000 nM
Compound 3: the middle estimate sits 2.5-fold (0.40 log units) above what was measured; measured number inside the range.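

Among these compounds, on the aromatic carbon next to the ring nitrogen, sulfanyl in place of amino gives an at least 16-fold lower number from compound 2 to compound 3 (1.22 log units; beyond the scatter) in this assay, the first reading of any substituent effect at this position. The true size of the step stays unknown, since compound 2 is held only by a limit of the assay and not by a number: the limit of > 200000 nM in this assay, at which 1 of the 3 values shown sits.

From the compounds shown here alone, whether sulfanyl is specifically required here remains open, as a hydroxyl or methylsulfanyl group on the same carbon could show. The contribution of the amino group that remains on the ring is also unresolved.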